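The source may hold more compounds than are shown below. What is called first, only, known or untested is meant among the compounds shown, and "the series" means these compounds.

Series notes. Compound 1 `CCC(C)c1cc(C)c(C(=O)N=C(N)N)cc1S(C)(=O)=O` gives 8 nM in a functional assay for inhibition of sodium/hydrogen exchanger (Oryctolagus cuniculus); on this read-out lower numbers stand for stronger inhibition and higher numbers for weaker inhibition. Compound 2 `Cc1cc(-c2ccc(F)cc2)c(S(C)(=O)=O)cc1C(=O)N=C(N)N` gives 36 nM in this assay, and compound 3 `Cc1cc(SC(C)(C)C)c(S(C)(=O)=O)cc1C(=O)N=C(N)N` gives 22 nM in this assay. Among the three numbers compound 3 stands second highest: compound 2 is nearest, within the scatter, while the gap to compound 1 is beyond it, as a 2.8-fold higher number from compound 1 to compound 3 (0.44 log units; beyond the scatter) shows.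

Compound 4 `Cc1cc(Oc2cccc(Cl)c2)c(S(C)(=O)=O)cc1C(=O)N=C(N)N` is not yet measured. Its change from compound 3 is 3-chlorophenoxy in place of (tert-butyl)sulfanyl on an aromatic carbon, placed on an aromatic carbon ortho to a methylsulfonyl group. Bearing on it: a 1.6-fold lower number from compound 2 to compound 3 (0.21 log units; within the scatter) shows that a six-membered aromatic ring on this carbon and (tert-butyl)sulfanyl sit within the scatter of each other, while a 4.5-fold higher number from compound 1 to compound 2 (0.65 log units; beyond the scatter) and a 2.8-fold higher number from compound 1 to compound 3 (0.44 log units; beyond the scatter) both mark modest higher numbers against sec-butyl. The entering 3-chlorophenoxy again carries a six-membered aromatic ring, so no large movement is expected. For compound 4 the expected step is a 1.6-fold higher number from compound 3 to compound 4 (0.20 log units; within the scatter), likely within the scatter. Compound 4 is therefore estimated at 35 nM in this assay, with a range of 12 nM to 100 nM.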

Compound 4, half-maximal inhibitory concentration: 21 nM
Estimate against measurement, compound 4: 1.7-fold (0.22 log units) above; measured number inside the range.
By their numbers in this assay, from the lowest: compound 1; then compounds 4, 3 and 2 (each within the scatter of the next).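

In this assay, the carbon ortho to a methylsulfonyl group takes 3-chlorophenoxy with no reading of difference from (tert-butyl)sulfanyl (a 1.0-fold lower number from compound 3 to compound 4 (0.02 log units; within the scatter)) or from 4-fluorophenyl (a 1.7-fold lower number from compound 2 to compound 4 (0.23 log units; within the scatter)). A group of 5 heavy atoms with no ring and groups carrying a six-membered aromatic ring therefore sit at one level here, with or without an oxygen or sulfur atom attached to this carbon. Against sec-butyl the step is modest (a 2.6-fold higher number from compound 1 to compound 4 (0.42 log units; beyond the scatter)), making this the third replacement beyond the scatter of that group, and no supporting data bear on the reason for either finding.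

The compounds shown leave open whether a longer alkyl chain would stay close to sec-butyl or join the level of the other three groups. An amine, a carboxylic acid or an unsubstituted phenoxy on this carbon also remains an open case.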